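Flavone ester series: aryl ester change, compound 4 estimate

The source may hold more compounds than are shown below. What is called first, only, known or untested is meant among the compounds shown, and "the series" means these compounds.

Measured compounds in a functional assay on cells (T-cell, Mus musculus, strain BALB/c) for inhibition, read by MTT assay, with a stated time of 72 h; a lower number here means a stronger inhibitor, a higher number a weaker inhibitor:
compound 1 `COC(=O)c1c(F)cccc1OC(=O)COc1cc(O)c2c(=O)cc(-c3ccccc3)oc2c1` gives 40300 nM
compound 2 `COC(=O)c1c(Cl)cc(Cl)cc1OC(=O)COc1cc(O)c2c(=O)cc(-c3ccccc3)oc2c1` gives 43600 nM
compound 3 `COC(=O)c1cc(O)ccc1OC(=O)COc1cc(O)c2c(=O)cc(-c3ccccc3)oc2c1` gives 29500 nM

Compound 3 holds the lowest of the three numbers in this assay, but the gap to compound 1 and to compound 2 each lies within the scatter, so no order among the three can be read from these values.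

Compound 4 `COC(=O)c1ccc(Cl)cc1OC(=O)COc1cc(O)c2c(=O)cc(-c3ccccc3)oc2c1` has not yet been measured. Relative to compound 3 the change is a group of 11 heavy atoms (8 carbon, 2 oxygen, 1 chlorine; one six-membered aromatic ring of carbon only) in place of a group of 11 heavy atoms (8 carbon, 3 oxygen; one six-membered aromatic ring of carbon only), on an oxygen next to a carbonyl group.

Going by the values given here, only one measured step touches the same position: a 1.4-fold lower number from compound 1 to compound 3 (0.14 log units; within the scatter). There the group carrying fluorine was exchanged for the group carrying a hydroxyl, and the number barely moved. Among the compounds with values here, compound 2, with two chlorines on that ring, shows 43600 nM against 29500 nM for compound 3, and this pair too sits within the scatter; no single-site step connects them. On this basis the step from compound 3 to compound 4, where a chlorine replaces the hydroxyl, is expected to stay within the scatter as well, with no clear direction; the expected step is a 1.3-fold higher number from compound 3 to compound 4 (0.11 log units; within the scatter).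

Compound 4 is therefore estimated at 38000 nM in this assay, with an expected range from 20000 nM to 72000 nM.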

Compound 4, half-maximal inhibitory concentration: 12400 nM
Compound 4: the middle estimate sits 3.1-fold (0.49 log units) above what was measured, outside the stated range (below it).
By their numbers in this assay, from the lowest: compound 4; then compounds 3, 1 and 2 (each within the scatter of the next).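

In this assay, going by these compounds alone, the aryl group on an oxygen next to a carbonyl group now gives a step beyond the scatter: a 2.4-fold lower number from compound 3 to compound 4 (0.38 log units; beyond the scatter) with 5-chloro-2-(methoxycarbonyl)phenyl entering, whereas the only earlier step at this place stayed within the scatter. The same group also sets compound 4 apart from the other two esters, with a 3.3-fold lower number from compound 1 to compound 4 (0.51 log units; beyond the scatter) for 5-chloro-2-(methoxycarbonyl)phenyl in place of 3-fluoro-2-(methoxycarbonyl)phenyl, and with a 3.5-fold lower number from compound 2 to compound 4 (0.55 log units; beyond the scatter) for hydrogen in place of chloro on an aromatic carbon, so the extra chloro of compound 2 goes with the loss of the lower number. Compound 4 is therefore the strongest inhibitor of the four, and the substitution on this ring matters more than the first three compounds showed, although chlorine alone does not secure the lower number, as compound 2 shows.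

Going by these compounds, whether a bromo, methyl or amino group in place of this chloro would match compound 4 remains open, as does the effect of a carboxylic acid in place of the methyl ester. Nothing available explains why these steps arise.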